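Swapping the amide amine: hydroxyethyl to methylsulfonylpiperazine

The source may report more compounds than this note shows. Statements on the series, on what has been measured and on what is new or still open speak of the compounds shown alone.

Of the compounds shown here, three sharing one core have been measured in an assay on HEK293 cells for displacement of a labelled ligand from NPC1-like intracellular cholesterol transporter 1 (Homo sapiens); on this read-out lower numbers stand for stronger inhibition and higher numbers for weaker inhibition. Compound 3 `O=C(CN1CN(c2ccccc2)C2(CCN(C(=O)c3ccc(C4CCCCC4)cc3)CC2)C1=O)NCCO` gives 2000 nM in this assay, the second highest of the three numbers. Its nearest neighbour is compound 1 `O=C(CN1CN(c2ccccc2)C2(CCN(C(=O)c3ccc(C4CCCCC4)cc3)CC2)C1=O)N1CCC(CO)CC1`, which gives 1100 nM; the step of a 1.8-fold higher number from compound 1 to compound 3 (0.26 log units; within the scatter) is a change of the amine on the amide carbonyl and is within the scatter. The furthest is compound 2 `CC(C)(C)c1ccc(C(=O)N2CCC3(CC2)C(=O)N(CC(=O)N2CCN(S(C)(=O)=O)CC2)CN3c2ccccc2)cc1`, which gives 19000 nM, a number beyond the scatter from compound 3.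

Compound 4 `CS(=O)(=O)N1CCN(C(=O)CN2CN(c3ccccc3)C3(CCN(C(=O)c4ccc(C5CCCCC5)cc4)CC3)C2=O)CC1` has not yet been measured. It differs from compound 3 in one place: 4-(methylsulfonyl)piperazin-1-yl in place of (2-hydroxyethyl)amino on a carbonyl carbon. Going by the values given here, the only measured step at this position, from compound 1 to compound 3, was within the scatter, so a change of the amide amine alone need not move the number. Among the compounds with values here, compound 2 carries the same 4-(methylsulfonyl)piperazin-1-yl group as compound 4 but differs from it in a second place, so no step to it can be drawn; its value is simply the highest of the three. Weighing both, compound 4 is expected to give a higher number, a step of a 4.0-fold higher number from compound 3 to compound 4 (0.60 log units; beyond the scatter). The estimate for compound 4 in this assay is 8000 nM, with a range from 2500 nM to 25000 nM.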

Compound 4, half-maximal inhibitory concentration: 6300 nM
Compound 4: middle estimate off by 1.3-fold (0.10 log units), on the high side; low and high end bracket the measured number.
By their numbers in this assay, from the lowest: compounds 1 and 3 (each within the scatter of the next); then compound 4; then compound 2.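

In this assay, 4-(methylsulfonyl)piperazin-1-yl on the carbonyl carbon in place of (2-hydroxyethyl)amino gives a 3.2-fold higher number from compound 3 to compound 4 (0.50 log units; beyond the scatter), and in place of 4-(hydroxymethyl)piperidin-1-yl it gives a 5.7-fold higher number from compound 1 to compound 4 (0.76 log units; beyond the scatter), so this position, whose only earlier step stayed within the scatter, can move the number after all. Compound 4 also opens a second comparison: with the 4-(methylsulfonyl)piperazin-1-yl group held fixed, cyclohexyl in place of tert-butyl on an aromatic carbon gives a 3.0-fold lower number from compound 2 to compound 4 (0.48 log units; beyond the scatter), so the number moves at this second place as well. No measurement shown here speaks to why either change shifts the number.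

Whether the higher number goes with the methylsulfonyl group, with the piperazine ring or with the loss of the hydroxyl cannot be told from these compounds, as all of these changes arrive together. On these data alone, a piperazine carrying acetyl in place of methylsulfonyl, or a morpholin-4-yl on the same carbonyl, would separate these parts, and it also remains open whether cyclohexyl and tert-butyl differ by a similar amount with (2-hydroxyethyl)amino on the carbonyl.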